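The compounds below may be only part of what the source reports. "The series", "measured", "known", "first", "only" and "open" are said of these compounds alone.

In a functional assay on K562 cells (Homo sapiens) for antiproliferative activity, read by MTT assay, with a stated time of 48 h (on this read-out lower numbers stand for stronger inhibition and higher numbers for weaker inhibition), compound 1 `O=C(CCCCCCn1cc(Nc2ncc(Cl)c(Nc3cccc(Cl)c3)n2)cn1)NO` gives 380 nM, compound 2 `COc1ccc(Nc2nc(Nc3cnn(CCCCCCC(=O)NO)c3)ncc2Cl)cc1` gives 620 nM and compound 3 `O=C(CCCCCn1cc(Nc2ncc(Cl)c(Nc3cccc(Cl)c3)n2)cn1)NO` gives 580 nM, so compound 1 stands within the scatter of both others. Compound 4 `O=C(CCCCCCn1cc(Nc2ncc(Cl)c(Nc3ccc(Cl)cc3)n2)cn1)NO` has not yet been measured. It differs from compound 1 in one place: 4-chlorophenyl in place of 3-chlorophenyl on a nitrogen on an aromatic ring. The closest measured step puts 4-methoxyphenyl in place of 3-chlorophenyl at that same place, and it is a 1.6-fold higher number from compound 1 to compound 2 (0.21 log units; within the scatter). The chain step, a 1.5-fold higher number from compound 1 to compound 3 (0.18 log units; within the scatter), bears on it less directly. Both stay within the scatter, so no change beyond the scatter is expected in this assay. The expected step is a 1.2-fold higher number from compound 1 to compound 4 (0.07 log units; within the scatter). Compound 4 is estimated at 450 nM, with an expected range from 200 nM to 1000 nM.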

Compound 4, half-maximal inhibitory concentration: 320 nM
For compound 4 the middle estimate is 1.4-fold (0.15 log units) above the measured one; the range from low to high includes it.
By their numbers in this assay, from the lowest: compounds 4, 1, 3 and 2 (each within the scatter of the next).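

In this assay, exchanging 3-chlorophenyl for 4-chlorophenyl gives a 1.2-fold lower number from compound 1 to compound 4 (0.07 log units; within the scatter), so moving the chlorine on this phenyl group produces no change that can be told from the scatter. With 4-substitution on that phenyl group, chloro in place of methoxy gives a 1.9-fold lower number from compound 2 to compound 4 (0.29 log units; within the scatter), which also stays within the scatter. No measurement on hand offers an explanation for either step.

The compounds shown leave open whether an amine or a carboxylic acid on this phenyl group would shift the number beyond the scatter. They also leave open how a longer chain would read alongside 4-chlorophenyl.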